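The source may hold more compounds than are shown below. What is called first, only, known or untested is meant among the compounds shown, and "the series" means these compounds.

Compound 1 `CC1CC/C(=N\Nc2ccc(Br)cc2)c2ncc(C(=O)O)c(=O)n21`: 2000 nM
Compound 2 `CCCCc1ccc(N/N=C2\CCC(C)n3c2ncc(C(=O)O)c3=O)cc1`: 1700 nM

In a functional assay (mast cells) for inhibition, with Rattus norvegicus as the target (a lower number here means that less compound is needed, a higher number that more compound is needed for the effect), compound 2 gives 1700 nM. Among the compounds with values here, that cannot be told apart from compound 1 at 2000 nM, so compound 2 stands level with the only other compound measured. Compound 3 `CC1CC/C(=N\Nc2ccc(C3CC3)cc2)c2ncc(C(=O)O)c(=O)n21` keeps the shared core but has cyclopropyl in place of butyl on an aromatic carbon, para to a large group: cyclopropyl in place of butyl on an aromatic carbon.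

Within the data shown here, only one measured step bears on this change, and it concerns the same aromatic carbon. Butyl replaced bromo there, giving a 1.2-fold lower number from compound 1 to compound 2 (0.07 log units; within the scatter), which is within the scatter. As far as these compounds go, with a single small step as the guide, no change beyond the scatter is expected in this assay, and the direction stays open. The expected result is a 1.1-fold higher number from compound 2 to compound 3 (0.02 log units; within the scatter). The estimated value for compound 3 is 1800 nM, with an expected range of 800 nM to 4000 nM.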

Compound 3, half-maximal effective concentration: 1000 nM
Compound 3: the middle estimate sits 1.8-fold (0.26 log units) above what was measured; the range from low to high includes it.
By their numbers in this assay, from the lowest: compounds 3, 2 and 1 (each within the scatter of the next).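

At this aromatic carbon, swapping an open chain for a small ring makes no clear difference in this assay: the change from butyl to cyclopropyl (a 1.7-fold lower number from compound 2 to compound 3 (0.23 log units; within the scatter)) stays within the scatter, and so does the change from bromo to cyclopropyl (a 2.0-fold lower number from compound 1 to compound 3 (0.30 log units; within the scatter)). Three quite different groups, bromo, butyl and the ring-bearing cyclopropyl, can therefore sit at this place on the shared core, and their numbers cannot be told apart. Nothing measured here accounts for these numbers.

The compounds shown leave open whether any group at this carbon can move the number beyond the scatter at all. An amine, a carboxylic acid or a much longer chain at the same place would put that question to the test.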